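The source may hold more compounds than are shown below. What is called first, only, known or untested is meant among the compounds shown, and "the series" means these compounds.

Compound 1 `COc1ccc(N)c(C2=NN(C(=O)C3CCC3)C(C)(C)S2)c1` and compound 2 `COc1ccc(N)c(C2=NN(C(=O)C3CCCC3)C(C)(C)S2)c1` share one core and differ only by cyclopentyl in place of cyclobutyl on a carbonyl carbon. In an assay on isolated protein for inhibition of Nitric oxide synthase, inducible (Homo sapiens), read by scintillation counting, with a stated time of 30 min, tested at 50 uM (a higher number here means more inhibition at the concentration tested (going by the name of the read-out), a lower number less inhibition), compound 1 gives 57.8%, and compound 2 gives 65%, so a number 7.2 percentage points higher from compound 1 to compound 2 (within the scatter). Compound 3 `CC1(C)SC(c2ccccc2N)=NN1C(=O)C1CCC1` carries a different core: the difference from compound 1 is hydrogen in place of methoxy on an aromatic carbon. In this assay compound 3 gives 46.9%, which is a number 10.9 percentage points lower from compound 1 to compound 3 (beyond the scatter). Compound 4 `CC1(C)SC(c2ccccc2N)=NN1C(=O)C1CCCC1` has not yet been measured. It is made from compound 3 by cyclopentyl in place of cyclobutyl on a carbonyl carbon, the same change that leads from compound 1 to compound 2. Because the earlier step was a number 7.2 percentage points higher from compound 1 to compound 2 (within the scatter), the step of a number 6.1 percentage points higher from compound 3 to compound 4 (within the scatter) is expected to be of about that size. Compound 4 is therefore estimated to give 53% in this assay, likely between 40% and 66%.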

Compound 4, a percentage reported as inhibition, at one concentration (the size of the read-out at that concentration, not a potency): 42.2%
Compound 4: the middle estimate sits 10.8 percentage points above what was measured, within the range that was stated.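

In this assay, cyclopentyl in place of cyclobutyl on a carbonyl carbon gives a number 4.7 percentage points lower from compound 3 to compound 4 (within the scatter), and this step agrees with the one seen on the core of compound 1: the same change on two cores in this assay, a number 7.2 percentage points higher (within the scatter) from compound 1 to compound 2 and a number 4.7 percentage points lower (within the scatter) from compound 3 to compound 4, 11.9 percentage points apart, within the scatter of two such steps. Hydrogen in place of methoxy on an aromatic carbon gives a number 22.8 percentage points lower from compound 2 to compound 4 (beyond the scatter), and this too agrees with the earlier step: the same change on two cores in this assay, a number 10.9 percentage points lower (beyond the scatter) from compound 1 to compound 3 and a number 22.8 percentage points lower (beyond the scatter) from compound 2 to compound 4, 11.9 percentage points apart, within the scatter of two such steps. Both changes therefore carry across these two pairs without a gap beyond the scatter, but the ring swap's steps are too small to show that it has any real effect, and four compounds say nothing about other cores.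

The compounds shown leave open how a cyclohexyl ring or an open butyl chain on the carbonyl carbon would read. They also leave open whether a hydroxyl in place of methoxy would keep the higher numbers.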